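Shifting the Aryl Substituent: Fluoro for Methoxy

This account rests on a few compounds, and the source may have more. Where it says the series, first, only, none or still open, it means among the compounds named here.

Measured compounds and their numbers in an ADME assay on HEK-293T cells (Homo sapiens) for antiproliferative activity, read by MTT assay, with a stated time of 48 h, in the presence of a further agent that is not named here; a higher number here means that more compound is tolerated, a lower number that less compound is tolerated:
Compound 1, `COc1ccc(-c2nn(-c3ccccc3)cc2C(=O)NOCc2ccccc2)cc1`, gives 201000 nM.
Compound 2, `COc1ccc(-c2nn(-c3ccccc3)cc2C(=O)NOCc2ccccc2Cl)cc1`, gives 586000 nM.
Compound 3, `COc1ccc(-c2nn(-c3ccccc3)cc2C(=O)NOCc2ccc(Cl)cc2Cl)cc1`, gives 545000 nM.

Among these three, compound 1 stands at the lowest number, with compound 3 nearest and compound 2 furthest; both gaps lie beyond the scatter, as a 2.7-fold higher number from compound 1 to compound 3 (0.43 log units; beyond the scatter) and a 2.9-fold higher number from compound 1 to compound 2 (0.46 log units; beyond the scatter) show. Between compound 2 and compound 3 the step is a 1.1-fold lower number from compound 2 to compound 3 (0.03 log units; within the scatter), within the scatter.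

The unmeasured compound 4, `O=C(NOCc1ccccc1)c1cn(-c2ccccc2)nc1-c1ccc(F)cc1`, differs from compound 1 in a different place: fluoro in place of methoxy on an aromatic carbon. Every measured step concerns the benzyl side of the shared core, where chloro enters; none touches the aryl ring that carries the methoxy. For the measured compounds named here, there is therefore no measured step that bears directly on the change to compound 4, and no direction can be read from the data.

With nothing in the measured steps to point otherwise, compound 4 is expected to land close to compound 1, with a step in this assay of about a 1.0-fold higher number from compound 1 to compound 4 (0.02 log units; within the scatter), not beyond the scatter. The estimate for compound 4 is 210000 nM, with a range from 80000 nM to 550000 nM.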

Compound 4, half-maximal cytotoxic concentration: 217000 nM
The estimate for compound 4 lay 1.0-fold (0.01 log units) below the measured number; low and high end bracket the measured number.
By their numbers in this assay, from the lowest: compounds 1 and 4 (each within the scatter of the next); then compounds 3 and 2 (each within the scatter of the next).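

The change from 4-methoxyphenyl to 4-fluorophenyl is the first step shown on the aryl ring of the shared core rather than on the benzyl side, and in this assay it gives a 1.1-fold higher number from compound 1 to compound 4 (0.03 log units; within the scatter). At this place, para to a large group, a methoxy with two heavy atoms and one hydrogen-bond acceptor gives way to a fluoro with one heavy atom and no acceptor, yet the number stays within the scatter, whereas chloro entering on the benzyl side gives a 2.9-fold higher number from compound 1 to compound 2 (0.46 log units; beyond the scatter). The data shown offer no measurement that would explain this outcome.

On these data alone, whether the number at this position stays equally close to that of compound 1 with other groups in place of the methoxy, such as an amine, a carboxylic acid or a longer alkoxy chain, remains open. Also open, as far as these compounds go, is whether fluoro in place of methoxy gives an equally small step when chloro is present on the benzyl side, as it is in compound 2 and compound 3.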